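Acetylation of the Ring Amino Group in a Nucleoside Series

This account rests on a few compounds, and the source may have more. Where it says the series, first, only, none or still open, it means among the compounds named here.

Compound 1 `O=c1ccn([C@@H]2O[C@H](CO)C[C@@H]2O)c(=O)[nH]1`: > 100 uM
Compound 2 `CC(=O)OC[C@@H]1C[C@H](OC(C)=O)[C@H](n2ccc(N)nc2=O)O1`: 30 uM
Compound 3 `CC(=O)O[C@H]1C[C@@H](CO)O[C@H]1n1ccc(N)nc1=O`: 20 uM

In a functional assay on CCRF S-180 cells (Mus musculus) (on this read-out lower numbers stand for an effect already at smaller amounts and higher numbers for an effect only at larger amounts of compound), compound 1 reaches only a limit, > 100 uM, so no number is known for it. Compound 2 gives 30 uM in this assay, and compound 3 gives 20 uM. Compound 3 thus holds the lower of the two numbers, but the step of a 1.5-fold lower number from compound 2 to compound 3 (0.18 log units; within the scatter) lies within the scatter, so the two cannot be told apart.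

Compound 4 `CC(=O)Nc1ccn([C@@H]2O[C@H](CO)C[C@@H]2OC(C)=O)c(=O)n1` differs from compound 3 by acetyl in place of hydrogen on a nitrogen on an aromatic ring. Within the data shown here, the only measured step, a 1.5-fold lower number from compound 2 to compound 3 (0.18 log units; within the scatter), swaps an acetyl for hydrogen on an oxygen on a saturated carbon and moves the number hardly at all. Among the measured compounds shown here, no measured step touches the nitrogen on the aromatic ring, so there is no direct precedent for this change.

Given that the one measured acetyl swap made no difference beyond the scatter, compound 4 is expected to stay close, with a step of a 1.5-fold higher number from compound 3 to compound 4 (0.18 log units; within the scatter). The estimate for compound 4 is therefore 30 uM, ranging from 8 uM to 120 uM.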

Compound 4, concentration for half-maximal effect: > 100 uM
Compound 4: a limit, no number; the forecaster's own chance of this, stated with the estimate: 20%; middle value at least 3.3-fold (0.52 log units) away from the limit.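

Acetyl on the nitrogen on the aromatic ring is not a neutral change in this assay, and the new step is an at least 5.0-fold higher number from compound 3 to compound 4 (0.69 log units; beyond the scatter). The earlier acetyl step sat on an oxygen on a saturated carbon instead, and it stayed within the scatter as a 1.5-fold lower number from compound 2 to compound 3 (0.18 log units; within the scatter); so in these two steps the same group counts for more on the nitrogen than on the oxygen. The new step gives only a lower bound on the change, as compound 4 stops at a limit: the limit of > 100 uM in this assay, at which 2 of the 4 values shown sit.

Only acetyl is shown on this nitrogen, so it stays open whether methyl or a longer acyl chain such as hexanoyl would have the same effect there. On these data alone, it also stays open whether the acetyl on the oxygen in compound 4 plays any part in this result.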